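Thiophen-2-yl to Phenyl: A Small Change, Flat Numbers

The source may report more compounds than this note shows. Statements on the series, on what has been measured and on what is new or still open speak of the compounds shown alone.

Of the compounds shown here, three have so far been measured in an ADME assay on Jurkat cells (Homo sapiens) for inhibition, read by WST assay, with a stated time of 48 h, tested at 10 uM; a lower number here means less inhibition, a higher number more inhibition at the concentration tested (going by the name of the read-out). Compound 1, `N#Cc1c(-c2ccccc2)nc(Nc2ccc(Cl)cc2)nc1N1CCCCC1`, gives 9%; compound 2, `N#Cc1c(-c2ccc(Cl)cc2)nc(SCc2ccccc2)nc1N1CCC(C(=O)c2ccccc2)CC1`, gives 6%; and compound 3, `COc1ccc(-c2nc(SCc3ccccc3)nc(NCc3cccs3)c2C#N)cc1`, gives 13%. All three numbers are low, meaning that at the concentration tested the cells were barely held back. Compound 3 shows the highest of the three numbers, yet its gap to compound 1 and its gap to compound 2 both lie within the usual scatter of repeated measurements, so on these data the inhibition in this assay is level across the three and no one number can be set apart from the others.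

Compound 4, `COc1ccc(-c2nc(SCc3ccccc3)nc(NCc3ccccc3)c2C#N)cc1`, has not yet been measured in this assay. It differs from compound 3 in one place: phenyl in place of thiophen-2-yl on a saturated chain carbon bound to a nitrogen on an aromatic ring. A single aromatic ring stays on the same saturated chain carbon; what changes is the ring size and the loss of the one sulfur atom. Going by the values given here, no pair of measured compounds differs in exactly this way, so there is no measured step to lean on. With all three numbers sitting near the floor and the change small, the step expected a number 1 percentage points lower from compound 3 to compound 4 (within the scatter) should be none beyond the scatter. Compound 4 is estimated at 12%, with a likely range from 2% to 24%.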

Compound 4, a percentage reported as inhibition, at one concentration (the size of the read-out at that concentration, not a potency): 5%
Compound 4: the middle estimate sits 7 percentage points above what was measured; the measured number falls inside the stated range.
By their numbers in this assay, from the lowest: compounds 4, 2, 1 and 3 (each within the scatter of the next).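

In this assay, going by these compounds alone, the change gives the first measured step at this position: phenyl in place of thiophen-2-yl on a saturated chain carbon bound to a nitrogen on an aromatic ring gives a number 8 percentage points lower from compound 3 to compound 4 (within the scatter). The earlier compounds shown here differed in several places at once and could not isolate any single group, whereas this pair shows that exchanging the five-membered aromatic ring with its sulfur for a six-membered ring of carbon only produces no change that can be told apart from the scatter. Nothing available bears on how either ring acts in these cells, so the result stands as a measurement without an explanation.

Going by these compounds, both compounds carry a single aromatic ring at this place, so it remains open how the assay would respond to a non-aromatic group there, such as a cyclohexyl ring, a carboxylic acid or a longer chain ending in an amine. On these data alone, it also remains open whether any group at this position can move the number beyond the scatter, or whether the same exchange would read the same way on a different core.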